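This account rests on a few compounds, and the source may have more. Where it says the series, first, only, none or still open, it means among the compounds named here.

Two compounds of this series have numbers in a functional assay on RPMI-8226 cells (Homo sapiens) for inhibition, read by sulforhodamine B assay, with a stated time of 48 h; a higher number here means a weaker inhibitor, a lower number a stronger inhibitor. Compound 1, with the structure `COc1cc(-c2nn(-c3cccc(NC(=O)c4ccc(Cl)c(C(F)(F)F)c4)c3)cc2-c2ccncc2)ccc1Cl`, gives 1620 nM in this assay. Compound 2, with the structure `COc1cc(-c2nn(-c3cccc(NC(=O)Nc4cccc(C(F)(F)F)c4)c3)cc2-c2ccncc2)ccc1Cl`, gives 340 nM in this assay and stands as the lowest of the two numbers, the nearest being compound 1, from which it is separated by a step beyond the scatter: a 4.8-fold lower number from compound 1 to compound 2 (0.68 log units; beyond the scatter). That step exchanges both the linker and the aryl group at once, so it does not isolate the effect of the chloro.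

Compound 3, with the structure `COc1cc(-c2nn(-c3cccc(NC(=O)Nc4ccc(Cl)c(C(F)(F)F)c4)c3)cc2-c2ccncc2)ccc1Cl`, has not been measured in this assay. It differs from compound 2 by chloro in place of hydrogen on an aromatic carbon. Among the measured compounds shown here, no measured step bears directly on this change; the only step available alters the carbonyl substituent together with the aryl. The step from compound 2 to compound 3 is therefore expected to be small, likely within the scatter, as a 1.1-fold lower number from compound 2 to compound 3 (0.03 log units; within the scatter). Compound 3 is estimated to give 320 nM in this assay, within the range 120 nM to 850 nM.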

Compound 3, half-maximal inhibitory concentration: 870 nM
For compound 3 the middle estimate is 2.7-fold (0.43 log units) below the measured one; the measured number lies above the stated range.
By their numbers in this assay, from the lowest: compound 2; then compounds 3 and 1 (each within the scatter of the next).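

In this assay, chloro in place of hydrogen on the aromatic carbon ortho to a trifluoromethyl group and para to a large group can now be read on its own, as a 2.6-fold higher number from compound 2 to compound 3 (0.41 log units; beyond the scatter). This single change is beyond the scatter, so the position is not indifferent to the swap within this pair, a point that the earlier step, which altered two features at once, could not show. With the 4-chloro-3-(trifluoromethyl)phenyl group held in place, placing an amino link on the carbonyl carbon gives a 1.9-fold lower number from compound 1 to compound 3 (0.27 log units; within the scatter), and this step lies within the scatter, so compound 1 and compound 3 are not separated by this assay. Nothing among the data shown accounts for either step.

The compounds shown leave open whether fluoro, bromo, methyl or methoxy at this position would track with chloro or with hydrogen. They also leave open whether the chloro step would hold if a methyl group or a nitrile stood in place of the trifluoromethyl group.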